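Replacing ethyl with cyclohexyl on an amide nitrogen

This account rests on a few compounds, and the source may have more. Where it says the series, first, only, none or still open, it means among the compounds named here.

Measured so far:
Compound 1, `CCNC(=O)c1nc(-c2ccc(CN(C)C)cc2)cnc1N`: > 1000000 nM
Compound 2, `CC(C)N1CCN(Cc2ccc(-c3cnc(N)c(C(=O)NC[C@@](C)(O)C(F)(F)F)n3)cc2)CC1`: > 1000000 nM

Both measurements come from a physicochemical assay for solubility, at pH 6.8; on this read-out lower numbers stand for lower solubility and higher numbers for higher solubility. The value for compound 1 is a limit of the assay, not a number, so compound 1 cannot be placed within the range of this assay; it is only known to sit at or beyond (the limit of > 1000000 nM in this assay, at which 2 of the 2 values shown sit). The value for compound 2 is likewise a limit and not a number. Among the measured compounds shown here, compound 2 shares no single-point difference with compound 1, so its result says only that both compounds reach the same limit.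

The unmeasured compound 3 is `CN(C)Cc1ccc(-c2cnc(N)c(C(=O)NC3CCCCC3)n2)cc1`. It differs from compound 1 in one place: cyclohexyl in place of ethyl on an amide-type nitrogen. For the measured compounds named here, no measured pair shows a step of this kind, so the expected size of the change in this assay cannot be taken from the data. The step of an at least 3.3-fold lower number from compound 1 to compound 3 (0.52 log units; beyond the scatter) is therefore an estimate that leans towards lower solubility while allowing that the limit may be reached again. For compound 3 the expected solubility is 300000 nM, in a range from 40000 nM to 1000000 nM.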

Compound 3, solubility: 190000 nM
Beside the measured number, compound 3's estimate is 1.6-fold (0.20 log units) above it, and the stated range covers the measured number.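

Swapping ethyl for cyclohexyl on the amide-type nitrogen gives, in this assay, an at least 5.2-fold lower number from compound 1 to compound 3 (0.72 log units; beyond the scatter), which shows that the read-out responds to the group at this position and that a change here can bring a compound down from the top of the range: the limit of > 1000000 nM in this assay, at which 2 of the 3 values shown sit.

The value for compound 1 is a limit and not a number, so this step gives only a minimum size, and the true difference could be larger. Among the compounds shown here, compound 3 is the first compound here with a value that is an actual number, so further changes to its amide group can be measured in either direction rather than disappearing at the limit.

A single step cannot separate the effect of the ring from that of the added carbon, and an open hexyl chain on the same nitrogen would help to tell these apart. From the compounds shown here alone, it also remains open whether a cyclohexyl ring carrying a hydroxyl group, or a piperidine ring in its place, would keep the read-out nearer to the value of compound 3 or move it back towards the limit.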